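Replacing the Amine Substituent of Compound 1: Expected Toxicity

The source may hold more compounds than are shown below. What is called first, only, known or untested is meant among the compounds shown, and "the series" means these compounds.

Compound 1 `C=C(C)C(=O)NC(=O)NC1=CS(=O)(=O)O[C@@]12[C@@H](CO[Si](C)(C)C(C)(C)C)O[C@@H](n1cc(C)c(=O)n(C)c1=O)[C@@H]2O[Si](C)(C)C(C)(C)C` holds the lowest of the two numbers reported in a functional assay on CCRF-CEM cells (Homo sapiens) (on this read-out higher numbers stand for lower toxicity in this test and lower numbers for higher toxicity in this test), where compound 1 gives 1200 nM. Compound 2 `Cc1cn([C@@H]2O[C@H](CO[Si](C)(C)C(C)(C)C)[C@@]3(OS(=O)(=O)C=C3NC(=O)c3ccccc3)[C@H]2O[Si](C)(C)C(C)(C)C)c(=O)n(C)c1=O` in this assay gives 4910 nM, which is a change of a 4.1-fold higher number from compound 1 to compound 2 (0.61 log units; beyond the scatter). For compound 3 `Cc1cn([C@@H]2O[C@H](CO[Si](C)(C)C(C)(C)C)[C@@]3(OS(=O)(=O)C=C3NCCC(=O)OCc3ccccc3)[C@H]2O[Si](C)(C)C(C)(C)C)c(=O)n(C)c1=O` this assay reports only a limit, > 250000 nM. Measured against the others, this amounts to an at least 200-fold higher number from compound 1 to compound 3 (2.31 log units; beyond the scatter) and an at least 50-fold higher number from compound 2 to compound 3 (1.70 log units; beyond the scatter).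

Compound 4 `Cc1cn([C@@H]2O[C@H](CO[Si](C)(C)C(C)(C)C)[C@@]3(OS(=O)(=O)C=C3NCC(=O)C(N)=O)[C@H]2O[Si](C)(C)C(C)(C)C)c(=O)n(C)c1=O` differs from compound 1 by (carbamoylcarbonyl)methyl in place of ((1-methylethenyl)carbonyl)carbamoyl on an amine nitrogen. The two large steps, both of which end at compound 3 and both of which likewise exchange an acyl-type substituent on the amine nitrogen for a carbon-linked chain, are the ones that bear on this change; the modest step between compound 1 and compound 2 matters less. A large rise in this assay is therefore expected for compound 4, estimated as a 130-fold higher number from compound 1 to compound 4 (2.10 log units; beyond the scatter). Compound 4 is expected to give about 150000 nM, within a range of 20000 nM to 1000000 nM, and it may well be reported only as a limit.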

Compound 4, half-maximal cytotoxic concentration: 9960 nM
The estimate for compound 4 lay 15-fold (1.18 log units) above the measured number, and the stated range ends above it.
By their numbers in this assay, from the lowest: compound 1; then compound 2; then compound 4. At a limit, above all of these: compound 3.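

A carbon-linked chain on this amine nitrogen does not by itself lift the number to the level of compound 3: in this assay, the exchange gives an 8.3-fold higher number from compound 1 to compound 4 (0.92 log units; beyond the scatter) and a 2.0-fold higher number from compound 2 to compound 4 (0.31 log units; beyond the scatter). What the chain carries at its far end therefore matters, as the carbamoylcarbonyl chain gives an at least 25-fold lower number from compound 3 to compound 4 (1.39 log units; beyond the scatter). The number for compound 3 is a limit, so this step has only a lower bound: the limit of > 250000 nM in this assay, at which 1 of the 4 values shown sits.

Going by these compounds, it remains open whether the high number of compound 3 depends on its benzyloxycarbonyl end or on the length of its chain. A chain of the same length ending in a carboxylic acid, or a plain ethyl group on this nitrogen, would help to separate these two contributions.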